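Swapping a heptyl chain for iodine on a shared urea core

The compounds below may be only part of what the source reports. "The series", "measured", "known", "first", "only" and "open" are said of these compounds alone.

Of the compounds shown here, three with the same core have been measured. Compound 1 `CCCCCc1ccc(NC(=O)N[C@H](C)c2ccccc2)cc1` gives 97% in an ADME assay on the whole organism with Oryza sativa as the target, tested at 10 uM; on this read-out higher numbers stand for a weaker effect at the one concentration tested and lower numbers for a stronger effect. Compound 2 `CCCCCCCc1ccc(NC(=O)N[C@H](C)c2ccccc2)cc1` gives 100%, and compound 3 `CCCCCCCc1ccc(NC(=O)N[C@@H](C)c2ccccc2)cc1` gives 99%. The step of a number 3 percentage points higher from compound 1 to compound 2 (within the scatter) adds ethyl in place of hydrogen on a saturated chain carbon, five bonds along the chain from an aromatic carbon. The step of a number 1 percentage points lower from compound 2 to compound 3 (within the scatter) turns on configuration alone, because of the fact that compounds 2 and 3 differ only in the configuration as drawn. Compound 2 thus stands at the top of the three numbers, but its neighbours sit within the scatter of it, so the three are indistinguishable here, and all point to a weak effect at the single concentration tested.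

Compound 4 `C[C@@H](NC(=O)Nc1ccc(I)cc1)c1ccccc1` has not been measured. It differs from compound 2 by iodo in place of heptyl on an aromatic carbon. Neither measured step touches this aromatic carbon, and both were within the scatter, so they give no guide to the size or direction of this change. On the numbers seen, a small step is expected, a number 8 percentage points lower from compound 2 to compound 4 (within the scatter), with wide uncertainty. Compound 4 is estimated at 92%, between 75% and 100%.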

Compound 4, a percentage reported as activity, at one concentration (the size of the read-out at that concentration, not a potency): 85%
Compound 4: middle estimate off by 7 percentage points, on the high side; the range from low to high includes it.
By their numbers in this assay, from the lowest: compound 4; then compounds 1, 3 and 2 (each within the scatter of the next).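

Going by these compounds alone, changing the group on this aromatic carbon gives the first step in this assay that lies beyond the scatter: the number falls, a number 15 percentage points lower from compound 2 to compound 4 (beyond the scatter), and likewise, a number 12 percentage points lower from compound 1 to compound 4 (beyond the scatter), so iodo gives a modestly stronger effect at the one concentration tested than either chain. Compound 1 and compound 2, with pentyl and heptyl, stay within the scatter of each other, so the change of chain length shows nothing here, while replacing either chain with iodo does. Nothing in the data shown explains why this swap lowers the number.

As far as these compounds go, whether the lower number comes from iodine itself or simply from the absence of a long chain remains open. A shorter chain such as methyl, or another halogen such as bromo or chloro, on this same carbon would help to separate the two.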